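Aryl swaps on a shared core: estimating compound 4

The compounds below may be only part of what the source reports. "The series", "measured", "known", "first", "only" and "open" are said of these compounds alone.

Measured so far:
compound 1 `CCCCCCCCCCCCCCCCCCNC(=O)[C@@H]1CSC(c2cccc(O)c2)N1`: 4000 nM
compound 2 `CCCCCCCCCCCCCCCCCCNC(=O)[C@@H]1CSC(c2cc(OC)c(OC)c(OC)c2)N1`: 2400 nM
compound 3 `CCCCCCCCCCCCCCCCCCNC(=O)[C@@H]1CSC(c2ccc(N(C)C)cc2)N1`: 3000 nM

In a functional assay on TSU-Pr1 cells (Homo sapiens) for antiproliferative activity, read by sulforhodamine B assay (on this read-out lower numbers stand for stronger inhibition and higher numbers for weaker inhibition), compound 3 gives the second highest of the three numbers; its nearest neighbour is compound 2, with a 1.3-fold higher number from compound 2 to compound 3 (0.10 log units; within the scatter), and its furthest is compound 1, with a 1.3-fold lower number from compound 1 to compound 3 (0.12 log units; within the scatter). Compound 4 `CCCCCCCCCCCCCCCCCCNC(=O)[C@@H]1CSC(c2c(OC)cc(OC)cc2OC)N1` carries 2,4,6-trimethoxyphenyl in place of 4-(dimethylamino)phenyl on a saturated ring carbon. Among the measured compounds shown here, all three aryl swaps seen so far, a 1.7-fold lower number from compound 1 to compound 2 (0.22 log units; within the scatter), a 1.3-fold lower number from compound 1 to compound 3 (0.12 log units; within the scatter) and a 1.3-fold higher number from compound 2 to compound 3 (0.10 log units; within the scatter), stayed within the scatter; the closest precedent is the move from 3-hydroxyphenyl to 3,4,5-trimethoxyphenyl, a 1.7-fold lower number from compound 1 to compound 2 (0.22 log units; within the scatter). No step beyond the scatter is therefore expected in this assay, and compound 4 is estimated at 3000 nM (range 1200 nM to 7500 nM), which would mean no change at the digits printed from compound 3 to compound 4 (within the scatter).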

Compound 4, half-maximal inhibitory concentration: 6100 nM
Compound 4: the middle estimate sits 2.0-fold (0.31 log units) below what was measured; measured number inside the range.
By their numbers in this assay, from the lowest: compounds 2, 3, 1 and 4 (each within the scatter of the next, the first and the last beyond it).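

In this assay, the aryl group on this saturated ring carbon now produces steps beyond the scatter: 2,4,6-trimethoxyphenyl gives a 2.0-fold higher number from compound 3 to compound 4 (0.31 log units; beyond the scatter) and a 2.5-fold higher number from compound 2 to compound 4 (0.41 log units; beyond the scatter), both modest. The second step exchanges one trimethoxyphenyl pattern for another, so the arrangement of the methoxy groups alone can shift the number at this position. Against 3-hydroxyphenyl, the same group stays within the scatter, with a 1.5-fold higher number from compound 1 to compound 4 (0.18 log units; within the scatter).

No available data explain the difference. Going by these compounds, whether a single methoxy group or a carboxylic acid on the aryl ring would separate further remains open.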